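From 4-fluorobenzyl to 4-ethylphenyl on a growth-inhibition scale

The compounds below may be only part of what the source reports. "The series", "measured", "known", "first", "only" and "open" are said of these compounds alone.

Of the compounds shown here, two have been read so far in a functional assay on MDA-MB-231 cells (Homo sapiens) for inhibition, read by CCK-8 assay, with a stated time of 48 h (on this read-out higher numbers stand for weaker inhibition of growth and lower numbers for stronger inhibition of growth), on MDA-MB-231 cells. Among the compounds with values here, compound 1 (`Cc1ccccc1Nc1nc(Nc2cccnc2)ncc1Cl`) gives 41200 nM as the only true number. Compound 2 (`CN1CCN(c2ccc(Nc3ncc(Cl)c(NCc4ccc(F)cc4)n3)nc2)CC1`) gives > 100000 nM and this is a limit of the assay, not a number. Compound 2 therefore stands at the end of the measured range, with no exact starting point for any step.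

Compound 3 (`CCc1ccc(Nc2nc(Nc3ccc(N4CCN(C)CC4)cn3)ncc2Cl)cc1`) has not yet been measured. It carries 4-ethylphenyl in place of 4-fluorobenzyl on a nitrogen on an aromatic ring. Within the data shown here, no measured pair shows what such a change does in this assay so the expectation is loose. Among the measured compounds shown here, a shift towards stronger inhibition of growth, beyond the usual scatter, is expected, resting on compound 1 at 41200 nM as the one reading inside the range. The estimated change is an at least 6.6-fold lower number from compound 2 to compound 3 (0.82 log units; beyond the scatter) and it counts from a limit, so its true size is open. The value expected for compound 3 is 15000 nM (estimated range 2500 nM to 80000 nM).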

Compound 3, concentration for 50% growth inhibition: 5560 nM
Compound 3: middle estimate off by 2.7-fold (0.43 log units), on the high side, within the range that was stated.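

In this assay, within the data shown here, 4-ethylphenyl in place of 4-fluorobenzyl on a nitrogen on an aromatic ring gives the first step that can be read at this position: an at least 17-fold lower number from compound 2 to compound 3 (1.25 log units; beyond the scatter). The two groups have the same count of heavy atoms, and each holds one six-membered aromatic ring of carbon only, yet this one exchange takes the read-out from a limit to a measured number, so the position is sensitive to what it carries. The step marks only the least the change can do, because compound 2 stands at a limit of the assay and not at a number: the limit of > 100000 nM in this assay, at which 1 of the 3 values shown sits.

The step exchanges the whole group, so the compounds shown cannot separate the part played by the fluorine and the ethyl from the part played by the benzyl carbon. On these data alone, how 4-fluorophenyl or unsubstituted benzyl on the same nitrogen would read stays open, as does whether a longer chain in place of the ethyl, or an amine on the ring, would carry the shift further.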